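Lengthening the chain: from compound 2 toward compound 3

The source may hold more compounds than are shown below. What is called first, only, known or untested is meant among the compounds shown, and "the series" means these compounds.

Measured so far:
Compound 1, `CCCCc1cc2ccccc2nc1-c1cc(-c2ccc(F)cc2)no1`, in a functional assay on PC-3 cells (Homo sapiens) for inhibition, read by MTT assay, with a stated time of 24 h (a lower number here means a stronger inhibitor, a higher number a weaker inhibitor), gives 26300 nM.
Compound 2, `CCc1cc2ccccc2nc1-c1cc(-c2ccc(C(F)(F)F)cc2)no1`, gives in this assay only a limit, > 100000 nM.

Compound 2 therefore stands at the limit of > 100000 nM in this assay, at which 1 of the 2 values shown sits, and as a limit rather than a number its distance from compound 1 cannot be set. Compound 3, `CCCCc1cc2ccccc2nc1-c1cc(-c2ccc(C(F)(F)F)cc2)no1`, differs from compound 2 by ethyl in place of hydrogen on a saturated chain carbon, two bonds along the chain from an aromatic carbon. Among the measured compounds shown here, no measured pair shows this change on its own, so its size is not known from the data. For the measured compounds named here, compound 1 carries the same longer chain and returns a number in this assay, which is the only hint that compound 3 might come back into the measurable range. The expected step of an at least 2.0-fold lower number from compound 2 to compound 3 (0.30 log units; that floor lies within the scatter) is a moderate fall in this assay, though compound 3 may itself end at the limit. Compound 3 is estimated at 50000 nM, in the range 15000 nM to 150000 nM.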

Compound 3, half-maximal inhibitory concentration: 10800 nM
Compound 3: middle estimate off by 4.6-fold (0.67 log units), on the high side, outside the stated range (below it).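

Ethyl in place of hydrogen on this saturated chain carbon, two bonds along the chain from an aromatic carbon, now has a measured effect in this assay as an at least 9.2-fold lower number from compound 2 to compound 3 (0.96 log units; beyond the scatter) and brings the butyl compound into the measurable range. This step has only a lower bound, since one of its ends is a limit and not a number: the limit of > 100000 nM in this assay, at which 1 of the 3 values shown sits. With the butyl chain held constant, trifluoromethyl in place of fluoro on an aromatic carbon gives a 2.4-fold lower number from compound 1 to compound 3 (0.39 log units; beyond the scatter) and so shows that this aromatic position also moves the value beyond the scatter.

On these data alone, whether a propyl chain or a longer chain such as hexyl would extend this fall, or an amine on the chain would reverse it, remains open. It also remains open whether the chain step holds with fluoro on the aromatic carbon, since the compounds shown include no ethyl partner for compound 1.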